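A few compounds are considered here, and "the series" means these few. Any claim that something is new, unique, unknown or untested is made for them only; others in the source may bear on it.

Measured so far in an assay for inhibition of Amine oxidase [flavin-containing] B (Rattus norvegicus); on this read-out higher numbers stand for weaker inhibition and lower numbers for stronger inhibition:
compound 1 `NC(=O)Cc1cc(=O)oc2cc(OCc3cccc(Cl)c3)ccc12` — 30 nM
compound 2 `NC(=O)Cc1cc(=O)oc2cc(OCc3cccc(O)c3)ccc12` — 1000 nM

Going by the values given here, compound 2 holds the highest number of the two, standing at 1000 nM against compound 1 at 30 nM; the only measured step, a 33-fold higher number from compound 1 to compound 2 (1.52 log units; beyond the scatter), is large and lies beyond the scatter.

Compound 3 `NC(=O)Cc1cc(=O)oc2cc(OCc3ccncc3)ccc12` differs from compound 2 by pyridin-4-yl in place of 3-hydroxyphenyl on a saturated chain carbon bound to an oxygen on an aromatic ring. Among the compounds with values here, no measured pair covers a change of this kind, so the expectation can rest only on compound 2 and on the one step of a 33-fold higher number from compound 1 to compound 2 (1.52 log units; beyond the scatter), which shows that the number moves far when the group on this carbon is exchanged. Since compound 2 carries the weakest value seen, and the group entering brings no hydrogen-bond donor, a step back toward lower numbers is expected, though not as far as compound 1; the expected step is a 3.3-fold lower number from compound 2 to compound 3 (0.52 log units; beyond the scatter). Compound 3 is therefore estimated at 300 nM, with a range from 60 nM to 1500 nM.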

Compound 3, half-maximal inhibitory concentration: 2000 nM
The estimate for compound 3 lay 6.7-fold (0.82 log units) below the measured number; measured number above the stated range.
By their numbers in this assay, from the lowest: compound 1; then compounds 2 and 3 (each within the scatter of the next).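

In this assay pyridin-4-yl in place of 3-hydroxyphenyl gives a 2.0-fold higher number from compound 2 to compound 3 (0.30 log units; within the scatter) so a group with no hydrogen-bond donor on this saturated chain carbon does not by itself bring the number back toward that of compound 1. Measured against 3-chlorophenyl, the same group gives a 67-fold higher number from compound 1 to compound 3 (1.82 log units; beyond the scatter) and of the three groups compared here, only the 3-chlorophenyl of compound 1 stands apart, beyond the scatter of the other two. Nothing available explains this result.

Going by these compounds, it remains open whether the low number of compound 1 is particular to chloro or also holds for 3-fluorophenyl, 3-bromophenyl, 3-methylphenyl or plain phenyl. Also open, on these data alone, is how pyridin-3-yl, or a phenyl ring carrying an amine or a carboxylic acid, would read on this carbon.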